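Removing the para-chloro from a biaryl sulfonamide

The source may hold more compounds than are shown below. What is called first, only, known or untested is meant among the compounds shown, and "the series" means these compounds.

Compound 3 `CC1CCN(C2CCN(S(=O)(=O)c3cccc(-c4ccc(Cl)cc4)c3)CC2)CC1` gives 15 nM in a functional assay on DLD-1 cells (Homo sapiens) for antiproliferative activity, read by CellTiter-Glo, with a stated time of 72 h (on this read-out higher numbers stand for weaker inhibition and lower numbers for stronger inhibition), the low end of the two numbers reported; its nearest neighbour is compound 1 `COc1ccccc1-c1cccc(S(=O)(=O)N2CCC(N3CCC(C)CC3)CC2)c1`, which gives 21 nM in this assay, and the step of a 1.4-fold lower number from compound 1 to compound 3 (0.15 log units; within the scatter) lies within the scatter. Compound 2 `COc1cccc(S(=O)(=O)N2CCC(N3CCC(C)CC3)CC2)c1` is reported in this assay only as a limit, > 5000 nM, as noted in the limit of > 5000 nM in this assay, at which 1 of the 3 values shown sits. From there the steps of an at least 230-fold higher number from compound 1 to compound 2 (2.37 log units; beyond the scatter) and an at least 330-fold lower number from compound 2 to compound 3 (2.52 log units; beyond the scatter) are both large, but each replaces the whole aryl group rather than a single substituent on it.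

Compound 4 `CC1CCN(C2CCN(S(=O)(=O)c3cccc(-c4ccccc4)c3)CC2)CC1` differs from compound 3 by hydrogen in place of chloro on an aromatic carbon. Among the measured compounds shown here, no measured step trims the aryl in this way; the only comparison between two aryl groups, a 1.4-fold lower number from compound 1 to compound 3 (0.15 log units; within the scatter), is within the scatter. Compound 4 is therefore expected to show no step beyond the scatter, with a 2.0-fold higher number from compound 3 to compound 4 (0.30 log units; within the scatter) as the estimated change. On that basis compound 4 is estimated at 30 nM in this assay, expected between 10 nM and 100 nM.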

Compound 4, half-maximal inhibitory concentration: 2 nM
Compound 4: middle estimate off by 15-fold (1.18 log units), on the high side; the measured number lies below the stated range.
By their numbers in this assay, from the lowest: compound 4; then compounds 3 and 1 (each within the scatter of the next). At a limit, above all of these: compound 2.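

Hydrogen in place of chloro, on an aromatic carbon para to a large group, is the first change shown that trims the aryl group rather than replacing it whole, and in this assay it gives a 7.5-fold lower number from compound 3 to compound 4 (0.88 log units; beyond the scatter). The two substituted aryl groups of compound 1 and compound 3, which lie within the scatter of each other, therefore do not mark the limit of this position: the plain phenyl also stands clear of the methoxy-bearing aryl, with an 11-fold lower number from compound 1 to compound 4 (1.02 log units; beyond the scatter). The widest step, an at least 2500-fold lower number from compound 2 to compound 4 (3.39 log units; beyond the scatter), starts from a limit and not from a number: the limit of > 5000 nM in this assay, at which 1 of the 4 values shown sits.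

The compounds shown leave open whether fluoro, methyl or an amine at this place would keep the number of compound 4. On these data alone, the effect of removing chloro is read on one core only, so whether it carries over to another core remains open.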